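Hydroxy-phenyl side chain on a quinazoline series: expected affinity

The source may hold more compounds than are shown below. What is called first, only, known or untested is meant among the compounds shown, and "the series" means these compounds.

Measured compounds:
Compound 1 `CCOC(C)COC1CCN(c2nc(N)c3cc(OC)c(OC)cc3n2)CC1` gives 0.99 nM in an assay on brain for displacement of a labelled ligand from Adrenergic receptor alpha-1 (Rattus norvegicus); on this read-out higher numbers stand for weaker inhibition and lower numbers for stronger inhibition.
Compound 2 `COc1cc2nc(N3CCC(OCC(C)(C)O)CC3)nc(N)c2cc1OC` gives 1.28 nM in this assay.
Compound 3 `CCOCC(OC1CCN(c2nc(N)c3cc(OC)c(OC)cc3n2)CC1)c1ccccc1` gives 10 nM in this assay.

Compound 3 stands with the highest number of the three, beyond the scatter from both others: the step of a 10-fold higher number from compound 1 to compound 3 (1.00 log units; beyond the scatter) and the step of a 7.8-fold higher number from compound 2 to compound 3 (0.89 log units; beyond the scatter) are both modest but clear.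

Compound 4 `COc1cc2nc(N3CCC(OCC(C)(O)c4ccccc4)CC3)nc(N)c2cc1OC` differs from compound 3 by 2-hydroxy-2-phenylpropyl in place of 2-ethoxy-1-phenylethyl on an oxygen on a saturated carbon. Two of the measured steps bear on this change. The step of a 1.3-fold higher number from compound 1 to compound 2 (0.11 log units; within the scatter) shows that exchanging an ethoxy-bearing chain for a hydroxy-bearing one of similar size leaves the number unchanged. The steps from compound 1 and compound 2 to compound 3 show that the chain carrying a phenyl ring raised the number modestly. Compound 4 keeps the phenyl ring but carries the hydroxy group found in compound 2, so it sits between compound 2 and compound 3 in structure, and the number is expected to lie between their values. The expected step is a 2.0-fold lower number from compound 3 to compound 4 (0.30 log units; within the scatter), a modest drop in the number, with wide uncertainty. Compound 4 is estimated at 5 nM, within a range of 1.5 nM to 20 nM.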

Compound 4, inhibition constant: 0.62 nM
Estimate against measurement, compound 4: 8.1-fold (0.91 log units) above; the measured number lies below the stated range.
By their numbers in this assay, from the lowest: compounds 4, 1 and 2 (each within the scatter of the next, the first and the last beyond it); then compound 3.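

On the oxygen on a saturated carbon, a phenyl ring does not by itself go with a high number in this assay: 2-hydroxy-2-phenylpropyl in place of 2-ethoxy-1-phenylethyl gives a 16-fold lower number from compound 3 to compound 4 (1.21 log units; beyond the scatter), so two chains that both carry the ring lie far apart. The earlier link between a phenyl-bearing chain and a higher number therefore rests on compound 3 alone, and compound 4 goes against it: with the hydroxy group kept, phenyl in place of methyl on the saturated chain carbon gives a 2.1-fold lower number from compound 2 to compound 4 (0.31 log units; beyond the scatter), while 1-hydroxy-1-phenylethyl in place of 1-ethoxyethyl gives a 1.6-fold lower number from compound 1 to compound 4 (0.20 log units; within the scatter). Nothing at hand explains the gap between the two phenyl-bearing chains.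

Compound 3 and compound 4 differ both in the hydroxy group and in where the phenyl ring sits on the chain, so it remains open which of the two accounts for the gap. Also open, going by these compounds, is what a 2-ethoxy-2-phenylpropyl chain, or an amine in place of the hydroxy group on the 2-hydroxy-2-phenylpropyl chain, would give in this assay.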